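The source may hold more compounds than are shown below. What is called first, only, known or untested is meant among the compounds shown, and "the series" means these compounds.

In an assay on liver for binding affinity to Alpha-1D adrenergic receptor (Homo sapiens), using microsomes (a higher number here means a weaker inhibitor, a lower number a stronger inhibitor), compound 1 `COC(=O)C1=C(C)NC(=O)N(C(=O)NCCCN2CCN(c3ccccc3O)CC2)C1c1ccc(F)c(F)c1` gives 31 nM, the lowest of the two numbers recorded. Going by the values given here, compound 2 `CCC1=C(C(N)=O)C(c2ccc(F)cc2F)N(C(=O)NCCCN2CCN(c3ccccc3C(N)=O)CC2)C(=O)N1` gives 1100 nM in this assay, a clearly higher figure, though no single-change step links the two. The step followed here goes from compound 1 to compound 3 `CCOc1ccccc1N1CCN(CCCNC(=O)N2C(=O)NC(C)=C(C(=O)OC)C2c2ccc(F)c(F)c2)CC1`, which has not yet been measured in this assay. The change is ethyl in place of hydrogen on an oxygen on an aromatic ring, the hydroxy becoming ethoxy and the 2-hydroxyphenyl becoming 2-ethoxyphenyl. Among the compounds with values here, no measured pair in this set covers that change, so the expectation rests on compound 1 alone. The step is expected to be small, a modest lowering of the number at most, or nothing beyond the scatter, as a 1.6-fold lower number from compound 1 to compound 3 (0.19 log units; within the scatter). Compound 3 is therefore estimated at 20 nM in this assay, within a range from 5 nM to 80 nM.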

Compound 3, inhibition constant: 14 nM
For compound 3 the middle estimate is 1.4-fold (0.15 log units) above the measured one; the measured number falls inside the stated range.
By their numbers in this assay, from the lowest: compound 3; then compound 1; then compound 2.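

In this assay, ethyl in place of hydrogen on an oxygen on an aromatic ring gives a 2.2-fold lower number from compound 1 to compound 3 (0.35 log units; beyond the scatter) as a modest step that goes beyond the scatter. The hydrogen of the hydroxy is therefore not needed for a low number in this series, since the 2-ethoxyphenyl compound sits lower than the 2-hydroxyphenyl one on the same core. No supporting measurement bears on why the number moves.

As far as these compounds go, whether the trend continues with a longer chain on this oxygen, such as propyl or butyl, or with a benzyl group, remains open, as does the effect of an amine in its place. This single pair also cannot say whether the same change would carry over to the core of compound 2.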